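Methoxy in Place of Fluoro: What Compound 3 May Show

The compounds below may be only part of what the source reports. "The series", "measured", "known", "first", "only" and "open" are said of these compounds alone.

compound 1, `O=C(NC(=S)Nc1ccc(F)cc1)c1cn(-c2ccccc2)nc1-c1ccc(F)cc1`: 3240 nM
compound 2, `O=C(NC(=S)Nc1ccc(Cl)cc1)c1cn(-c2ccccc2)nc1-c1ccc(Cl)cc1`: 3260 nM

Both numbers come from a functional assay on NCI-H460 cells (Homo sapiens) for inhibition, read by CCK-8 assay, with a stated time of 48 h; on this read-out lower numbers stand for stronger inhibition and higher numbers for weaker inhibition. Compound 1 stands on the lowest of the two numbers, yet compound 2 sits within the scatter of it, so the two are not told apart. Compound 3, `COc1ccc(-c2nn(-c3ccccc3)cc2C(=O)NC(=S)Nc2ccc(F)cc2)cc1`, has not been measured; it differs from compound 1 by methoxy in place of fluoro on an aromatic carbon. Going by the values given here, no measured pair bears on this change, so no step beyond the scatter is expected in this assay in either direction. Compound 3 is estimated at 3000 nM, between 1200 nM and 8000 nM. The expected step is a 1.1-fold lower number from compound 1 to compound 3 (0.03 log units; within the scatter).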

Compound 3, half-maximal inhibitory concentration: 3050 nM
The estimate for compound 3 lay 1.0-fold (0.01 log units) below the measured number; the measured number falls inside the stated range.
By their numbers in this assay, from the lowest: compounds 3, 1 and 2 (each within the scatter of the next).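

Exchanging fluoro for methoxy on an aromatic carbon, para to a large group, gives a 1.1-fold lower number from compound 1 to compound 3 (0.03 log units; within the scatter) in this assay. This position therefore takes the 4-methoxyphenyl group in place of 4-fluorophenyl with no step beyond the scatter, a point compounds 1 and 2 alone could not show. No measurement shown here speaks to why this is so.

As far as these compounds go, whether an amine or a carboxylic acid at this position would also leave the number within the scatter remains open. So does the effect of methoxy in place of the other fluoro of compound 1.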